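Extending Compound 1 at a Nitrogen on an Aromatic Ring

The compounds below may be only part of what the source reports. "The series", "measured", "known", "first", "only" and "open" are said of these compounds alone.

Of the compounds shown here, three have been measured in a functional assay on the whole organism (strain albino) for inhibition, with Rattus norvegicus as the target, read by paw edema, with stated times of 30 min and 5 h, at a dose of 100 mg/kg by the oral route; a lower number here means less inhibition, a higher number more inhibition at the dose given (going by the name of the read-out). Compound 1 `Nc1ccc(C(=O)/C=C/c2ccc(Cl)cc2)cc1` gives 54% in this assay, the highest of the three numbers. Compound 3 `COc1ccc(/C=C/C(=O)c2ccc(NC(=O)CO[N+](=O)[O-])cc2)cc1` gives 46% in this assay, a number that lies within the usual scatter of that of compound 1, so the two cannot be ordered. Compound 2 `Nc1ccc(C(=O)/C=C/c2ccco2)cc1` gives 30% in this assay, a number that falls beyond the scatter below compound 1.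

Compound 4 `CC(O[N+](=O)[O-])C(=O)Nc1ccc(C(=O)/C=C/c2ccc(Cl)cc2)cc1` has not been measured. It differs from compound 1 in one place: a group of 8 heavy atoms (3 carbon, 1 nitrogen, 4 oxygen; no ring) in place of a hydrogen atom, on a nitrogen on an aromatic ring. Among the measured compounds shown here, no pair of measured compounds differs in a single place, so no measured step guides the prediction directly. What can be said is that compound 3 also bears a group attached at a nitrogen on an aromatic ring and its value of 46% sits within the scatter of compound 1.

On that basis the step of a number 4 percentage points lower from compound 1 to compound 4 (within the scatter) is expected to be small, in either direction, and not beyond the scatter. Compound 4 is estimated to give 50% in this assay, with a range from 35% to 65%.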

Compound 4, a percentage reported as inhibition, in the whole organism at one dose (the size of the read-out at that dose, not a potency): 56%
Estimate against measurement, compound 4: 6 percentage points below; low and high end bracket the measured number.
By their numbers in this assay, from the lowest: compound 2; then compounds 3, 1 and 4 (each within the scatter of the next).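

In this assay, placing the group of 8 heavy atoms on the nitrogen on an aromatic ring in place of a hydrogen atom gives a number 2 percentage points higher from compound 1 to compound 4 (within the scatter), so compound 1 and compound 4 cannot be ordered, and at this dose the read-out does not separate the substituted nitrogen from the free amine. Among the compounds shown here, this is the only step that isolates a change at this position: compound 3 also carries a group on such a nitrogen, but it differs from compound 1 in other places as well, so it could not show this on the core of compound 1 alone. No measurement is available that would explain why the read-out stays within the scatter across this change.

The compounds shown leave open whether the whole group matters to this result or whether a plain acetyl group, a hydroxyacetyl group or a longer chain on the same nitrogen would give a similar number. They also leave open whether the same change would leave the read-out within the scatter on the core of compound 2, which sits lower in this assay.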